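This account rests on a few compounds, and the source may have more. Where it says the series, first, only, none or still open, it means among the compounds named here.

Measured so far, in a functional assay on the whole organism with Rattus norvegicus as the target, in the maximal electroshock model; a higher number here means that more compound is needed for the effect, a lower number that less compound is needed:
- compound 1, `CNc1ncnc2c1ncn2Cc1ccccc1C`, gives 10 mg/kg
- compound 2, `Fc1ccccc1Cn1cnc2c(NCC3CC3)ncnc21`, gives 4.3 mg/kg

Among the compounds with values here, two compounds share a core and differ in more than one place, so no single step between them can be read. Of the two numbers, compound 2 gives the lower one in this assay, and the gap to compound 1 lies beyond the usual scatter of the measurement.

The next compound, compound 3, `Fc1ccccc1Cn1cnc2c(NC3CC3)ncnc21`, has not yet been measured in this assay. It differs from compound 2 in one place only: cyclopropyl in place of cyclopropylmethyl on a nitrogen on an aromatic ring. Cut one bond further out, the same difference reads as cyclopropylamino in place of (cyclopropylmethyl)amino. Within the data shown here, nothing among the measured compounds shows what this change does on its own, since the pair compound 1 and compound 2 differ elsewhere as well.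

With no guide from the data, the expected step of a 1.4-fold higher number from compound 2 to compound 3 (0.14 log units; within the scatter) is small, without a clear direction and likely within the scatter. For compound 3 the estimate in this assay is 6 mg/kg, with a range from 2.5 mg/kg to 15 mg/kg.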

Compound 3, dose for half-maximal effect: 5 mg/kg
Estimate against measurement, compound 3: 1.2-fold (0.08 log units) above; the measured number falls inside the stated range.
By their numbers in this assay, from the lowest: compounds 2, 3 and 1 (each within the scatter of the next, the first and the last beyond it).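

Within the data shown here, replacing cyclopropylmethyl with cyclopropyl on a nitrogen on an aromatic ring gives, in this assay, a 1.2-fold higher number from compound 2 to compound 3 (0.07 log units; within the scatter), so this is the first change that can be read on its own, and the assay does not tell these two groups apart. Both groups keep the three-membered carbon ring, and going from 4 heavy atoms to 3 at this place leaves the dose needed for the effect within the normal spread of repeated measurements, which suggests that this small trim is tolerated here. Nothing at hand explains why the two groups read alike.

As far as these compounds go, it remains open whether the same holds for groups of a different kind at this nitrogen, such as an open ethyl group, a longer chain like n-butyl, a larger ring like cyclohexyl, or a chain ending in an amine. From the compounds shown here alone, compound 1 differs from compound 2 and compound 3 in more than one place, so its gap to them cannot be divided among single changes, and the contribution of each of those differences remains unknown.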